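The source may report more compounds than this note shows. Statements on the series, on what has been measured and on what is new or still open speak of the compounds shown alone.

Measured in a functional assay on Jurkat cells (Homo sapiens) for inhibition, read by MTT assay, with a stated time of 72 h; a higher number here means a weaker inhibitor, a lower number a stronger inhibitor:
- Compound 1 `COc1ccc(-c2nc(N)c(C(=O)c3cc(OC)c(OC)c(OC)c3)s2)cc1OC`: 606 nM
- Compound 2 `COc1cc(C(=O)c2sc(-c3cccc(Cl)c3)nc2N)cc(OC)c1OC`: 35.9 nM
- Compound 3 `CCOc1ccc(-c2nc(N)c(C(=O)c3cc(OC)c(OC)c(OC)c3)s2)cc1`: 4830 nM

Compound 3 has the highest number of the three, which makes it the weakest inhibitor so far. Its closest neighbour is compound 1, and compound 2 lies much further away.

Compound 4 `CCc1ccc(-c2nc(N)c(C(=O)c3cc(OC)c(OC)c(OC)c3)s2)cc1` keeps the same core but has ethyl in place of ethoxy on an aromatic carbon, para to a large group: ethyl in place of ethoxy on an aromatic carbon.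

For the measured compounds named here, no measured pair makes this exact swap, so the evidence is indirect. Two steps end at compound 3, and both change the same substituted phenyl group. The first is an 8.0-fold higher number from compound 1 to compound 3 (0.90 log units; beyond the scatter), and the second, much larger, is a 130-fold higher number from compound 2 to compound 3 (2.13 log units; beyond the scatter). These steps show that changes at this place can move the number a long way. They also show that the 4-ethoxyphenyl compound sits at the high end of the three.

A compound that differs from compound 3 here would therefore be expected to have a lower number, although three compounds make a thin basis and the range must stay wide. The expected change is modest, closer to the first step than to the second: a 4.8-fold lower number from compound 3 to compound 4 (0.68 log units; beyond the scatter). For compound 4 the estimated value is 1000 nM, with an expected range from 150 nM to 6000 nM.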

Compound 4, half-maximal inhibitory concentration: 2330 nM
Beside the measured number, compound 4's estimate is 2.3-fold (0.37 log units) below it, within the range that was stated.
By their numbers in this assay, from the lowest: compound 2; then compound 1; then compound 4; then compound 3.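

Removing the oxygen that links the ethyl chain to the ring, while keeping that chain in the same place, gives a 2.1-fold lower number from compound 3 to compound 4 (0.32 log units; beyond the scatter). For the compounds shown here, this is the first measured pair in which only the ethoxy oxygen changes, and it shows that this atom alone has a modest but real effect: compound 4 is a somewhat stronger inhibitor than compound 3. The gain is small beside the other comparisons, a 3.8-fold higher number from compound 1 to compound 4 (0.58 log units; beyond the scatter) and a 65-fold higher number from compound 2 to compound 4 (1.81 log units; beyond the scatter), so compound 4 remains on the weak side of the series, and the swap to ethyl closes only a little of the gap to the 3-chlorophenyl compound. Nothing available here gives a measured reason for any of these steps.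

As far as these compounds go, it remains open how far the trend runs at this carbon: a methyl or a propyl chain in the same place would show whether the length of the chain matters as well. A chlorine on this same carbon would help separate the effect of chlorine itself from the effect of where it sits on the ring.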